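Hydroxy to fluoro on compound 3

The compounds below may be only part of what the source reports. "The series", "measured", "known", "first", "only" and "open" are said of these compounds alone.

Measured in a functional assay on HeLa cells (Homo sapiens) for antiproliferative activity, read by sulforhodamine B assay, with a stated time of 48 h; a lower number here means a stronger inhibitor, a higher number a weaker inhibitor:
- compound 1 `COc1ccc2nc(-c3ccc(N/C=C\C(=O)c4ccc(OC)c(O)c4)c(C)c3)sc2c1`: 12000 nM
- compound 2 `COc1ccc(C(=O)/C=C\Nc2ccc(-c3nc4cc(OC)c(OC)c(OC)c4s3)cc2C)cc1[N+](=O)[O-]`: 13400 nM
- compound 3 `COc1ccc2nc(-c3ccc(N/C=C\C(=O)c4ccc(OC)c(O)c4)cc3)sc2c1`: 6900 nM

Compound 3 stands at 6900 nM, and all three compounds lie within the scatter of one another, so this assay does not order them.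

The unmeasured compound 4 `COc1ccc2nc(-c3ccc(N/C=C\C(=O)c4ccc(OC)c(F)c4)cc3)sc2c1` differs from compound 3 in one place: fluoro in place of hydroxy on an aromatic carbon, ortho to a methoxy group and meta to a large group, which turns 3-hydroxy-4-methoxyphenyl into 3-fluoro-4-methoxyphenyl (fluoro in place of hydroxy on an aromatic carbon).

For the measured compounds named here, only one measured step bears on this, and only indirectly: a 1.7-fold lower number from compound 1 to compound 3 (0.24 log units; within the scatter). That step is hydrogen in place of methyl on an aromatic carbon and stays within the scatter. Going by the values given here, no measured step replaces the hydroxy, so the data give neither size nor direction for this change directly. With compound 3 at 6900 nM and the spread of the series so narrow, no step beyond the scatter is expected, with only a slight lean towards a higher number. The expected change is a 1.3-fold higher number from compound 3 to compound 4 (0.12 log units; within the scatter). For compound 4 the estimate is 9000 nM, with an expected range of 3500 nM to 24000 nM.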

Compound 4, half-maximal inhibitory concentration: 500 nM
Compound 4: the middle estimate sits 18-fold (1.26 log units) above what was measured; the whole stated range lies above it.
By their numbers in this assay, from the lowest: compound 4; then compounds 3, 1 and 2 (each within the scatter of the next).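

In this assay, for the compounds shown here, this position responds strongly where the earlier change did not: the exchange of hydroxy for fluoro gives a 14-fold lower number from compound 3 to compound 4 (1.14 log units; beyond the scatter) and so lies beyond the scatter, whereas the only earlier step, a 1.7-fold lower number from compound 1 to compound 3 (0.24 log units; within the scatter) and the exchange of methyl for hydrogen, does not. The change takes 3-hydroxy-4-methoxyphenyl to 3-fluoro-4-methoxyphenyl, removing a group counted with a hydrogen-bond donor and a hydrogen-bond acceptor and entering one counted with neither, so the hydroxy is not needed for antiproliferative activity at this level of the series. No evidence at hand bears on why this single-atom exchange gives so large a step.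

Going by these compounds, whether the step follows from the fluoro itself or from the loss of the hydroxy stays open, and a hydrogen, a chloro or an amine on the same aromatic carbon would separate the two readings. Also open, on these data alone, is whether the same exchange gives a step of similar size on the methyl-bearing core of compound 1.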